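Dechlorination of a dichloro purine analogue: expected cytotoxicity

The compounds below may be only part of what the source reports. "The series", "measured", "known", "first", "only" and "open" are said of these compounds alone.

Measured so far:
compound 1 `ClCc1ccc(Cn2cnc3c(Cl)ncnc32)cc1` — 25100 nM
compound 2 `ClCc1ccccc1Cn1cnc2c(Cl)nc(Cl)nc21` — 750 nM

Of the compounds shown here, two have been measured in a functional assay on HCT-116 cells (Homo sapiens) for cytotoxicity, read by sulforhodamine B assay, with a stated time of 48 h; a higher number here means that more compound is tolerated, a lower number that less compound is tolerated. Compound 1 `ClCc1ccc(Cn2cnc3c(Cl)ncnc32)cc1` gives 25100 nM in this assay. Compound 2 `ClCc1ccccc1Cn1cnc2c(Cl)nc(Cl)nc21` gives 750 nM and stands at the lowest of the two numbers; compound 1 sits a long way higher, a gap that lies beyond the scatter. Going by the values given here, no two measured compounds differ in only one place, so no single structural change has yet been followed by a measurement.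

Compound 3 `ClCc1ccccc1Cn1cnc2c(Cl)ncnc21` remains to be measured. It differs from compound 2 by hydrogen in place of chloro on an aromatic carbon of a six-membered aromatic ring with 2 nitrogen, part of a fused or bridged system of two rings, between two ring nitrogen atoms. No measured pair shows what this change does in this assay, so the expected step from compound 2 to compound 3 is a 2.7-fold higher number from compound 2 to compound 3 (0.43 log units; beyond the scatter), read as a moderate rise in the number that is estimated rather than grounded in a shown step. The estimate for compound 3 in this assay is 2000 nM, with a range from 600 nM to 8000 nM expected to hold the outcome.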

Compound 3, concentration lethal to 50% of the cells: 7080 nM
Beside the measured number, compound 3's estimate is 3.5-fold (0.55 log units) below it; the measured number falls inside the stated range.
By their numbers in this assay, from the lowest: compound 2; then compound 3; then compound 1.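

In this assay, going by these compounds alone, the first single change that can be followed is hydrogen in place of chloro on the aromatic carbon between two ring nitrogen atoms, and it gives a 9.4-fold higher number from compound 2 to compound 3 (0.97 log units; beyond the scatter). Within the data shown here, the chloro group at this position therefore goes with less compound being tolerated, though this rests on a single pair with one shared remainder of the structure, and the earlier compounds offered no pair from which to read it. No measurement at hand bears on what lies behind the size of this step.

With only chloro and hydrogen shown at this position, it remains open whether another group there, such as an amine, a methoxy group or a longer chain, would give a number nearer that of compound 2 or that of compound 3. Also open, on these data alone, are whether the same swap gives a step of similar size with the chloromethyl group placed as in compound 1, and how the numbers would move if a hydroxymethyl group took the place of the chloromethyl group.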